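The compounds below may be only part of what the source reports. "The series", "measured", "known", "first", "only" and "open" are said of these compounds alone.

In an assay on isolated protein for inhibition of malate dehydrogenase, mitochondrial (Sus scrofa), with stated times of 45 min and 30 min (on this read-out higher numbers stand for weaker inhibition and lower numbers for stronger inhibition), compound 1 `O=S(=O)(Nc1ccc2oc(-c3ccccc3)nc2c1)c1ccccc1O` gives > 63000 nM, which is a limit of the assay rather than a number. Compound 2 `Cc1ccccc1S(=O)(=O)Nc1ccc2oc(-c3ccccc3)nc2c1` likewise reaches only the limit > 63000 nM. Compound 3 `COc1ccc(S(=O)(=O)Nc2ccc3oc(-c4ccccc4)nc3c2)cc1` also stops at the limit > 63000 nM. The three measured steps, a step that the two limits leave unreadable from compound 1 to compound 2, a step that the two limits leave unreadable from compound 1 to compound 3 and a step that the two limits leave unreadable from compound 2 to compound 3, cannot be sized, as all three values sit at the limit of > 63000 nM in this assay, at which 3 of the 3 values shown sit. Compound 4 `COc1ccc(Cl)cc1S(=O)(=O)Nc1ccc2oc(-c3ccccc3)nc2c1` differs from compound 3 by 5-chloro-2-methoxyphenyl in place of 4-methoxyphenyl on a sulfonyl sulfur. No readable step bears on this change, so neither a direction nor a size beyond the scatter can be drawn from the data. Compound 4 is therefore expected to show in this assay a step that the limit leaves unreadable from compound 3 to compound 4. Compound 4 is estimated at 70000 nM, ranging from 20000 nM to 200000 nM, most likely again a limit.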

Compound 4, half-maximal inhibitory concentration: > 63000 nM
Compound 4: no number, only a limit; the forecaster's own chance of this, stated with the estimate: 80%; the middle value lies beyond the limit too.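

No step can be read between compound 4 and compound 1, compound 2 or compound 3, as all four values are limits: the limit of > 63000 nM in this assay, at which 4 of the 4 values shown sit.

In this assay the compounds shown leave open whether any group on the sulfonyl sulfur gives a measurable inhibition.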